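The source may hold more compounds than are shown below. What is called first, only, known or untested is meant among the compounds shown, and "the series" means these compounds.

Working notes on the series. Three measured analogues share one core and differ only in the substituent on the outer aryl ring. In a functional assay on Mahlavu cells (Homo sapiens) for antiproliferative activity, read by sulforhodamine B assay, with a stated time of 72 h (on this read-out lower numbers stand for stronger inhibition and higher numbers for weaker inhibition), compound 1 `Cc1cccc(COc2ccc(-c3cc(CN4CCN(Cc5ccc(C(F)(F)F)cc5)CC4)no3)cc2)c1` gives 2500 nM. In this assay compound 2 `FC(F)(F)c1ccc(CN2CCN(Cc3cc(-c4ccc(OCc5cccc(Cl)c5)cc4)on3)CC2)cc1` gives 4100 nM, and compound 3 `FC(F)(F)c1ccc(CN2CCN(Cc3cc(-c4ccc(OCc5ccc(Cl)cc5)cc4)on3)CC2)cc1` gives 3700 nM. Among these three numbers compound 3 stands second highest. Its nearest neighbour is shown by a 1.1-fold lower number from compound 2 to compound 3 (0.04 log units; within the scatter), its furthest by a 1.5-fold higher number from compound 1 to compound 3 (0.17 log units; within the scatter). The next step leads to compound 4 `N#Cc1ccc(COc2ccc(-c3cc(CN4CCN(Cc5ccc(C(F)(F)F)cc5)CC4)no3)cc2)cc1`: cyano in place of chloro on an aromatic carbon. All measured steps at this position, a 1.6-fold higher number from compound 1 to compound 2 (0.21 log units; within the scatter), a 1.5-fold higher number from compound 1 to compound 3 (0.17 log units; within the scatter) and a 1.1-fold lower number from compound 2 to compound 3 (0.04 log units; within the scatter), fell within the scatter, so no step beyond the scatter is expected in this assay for this change. Compound 4 is therefore expected to give 3500 nM, with a range from 1800 nM to 7000 nM, amounting to an expected 1.1-fold lower number from compound 3 to compound 4 (0.02 log units; within the scatter).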

Compound 4, half-maximal inhibitory concentration: 4300 nM
For compound 4 the middle estimate is 1.2-fold (0.09 log units) below the measured one; low and high end bracket the measured number.
By their numbers in this assay, from the lowest: compounds 1, 3, 2 and 4 (each within the scatter of the next).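

In this assay the first nitrile at this position, with a hydrogen-bond acceptor entering where chloro held none, stays within the scatter (a 1.2-fold higher number from compound 3 to compound 4 (0.07 log units; within the scatter)). The 4-cyanophenyl group also stays within the scatter of 3-chlorophenyl (a 1.0-fold higher number from compound 2 to compound 4 (0.02 log units; within the scatter)) and 3-methylphenyl (a 1.7-fold higher number from compound 1 to compound 4 (0.24 log units; within the scatter)), so all four outer aryl groups now lie within the scatter of one another. Nothing available on these compounds accounts for this flatness. Open, on these data alone, is whether an amine or a carboxylic acid on this ring would give a step beyond the scatter, and whether a longer chain to the outer ring would do so.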